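Carbamate in place of ester side chain on the shared core

The compounds below may be only part of what the source reports. "The series", "measured", "known", "first", "only" and "open" are said of these compounds alone.

In a functional assay on blood (Homo sapiens) for inhibition (a higher number here means a weaker inhibitor, a lower number a stronger inhibitor), compound 2 (`COC(=O)COc1ccc(OCc2ccc3ccccc3n2)cc1C1(c2ccccc2)CCCC1`) gives 890 nM and stands within the scatter of compound 1 (`Oc1ccc(OCc2ccc3ccccc3n2)cc1C1(c2ccccc2)CC2CCC1C2`) at 580 nM in this pair. Compound 3 (`O=C(Nc1cccnc1)Oc1ccc(OCc2ccc3ccccc3n2)cc1C1(c2ccccc2)CCCC1`) carries (pyridin-3-yl)carbamoyl in place of (methoxycarbonyl)methyl on an oxygen on an aromatic ring. Among the compounds with values here, no measured pair covers this change, so the data offer no direction and the expectation remains rough. Expected in this assay is a 1.3-fold lower number from compound 2 to compound 3 (0.10 log units; within the scatter) and this stays within the scatter. Compound 3 is estimated at 700 nM with 200 nM to 2400 nM as the expected range.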

Compound 3, half-maximal inhibitory concentration: 52 nM
Compound 3: middle estimate off by 13-fold (1.13 log units), on the high side; the whole stated range lies above it.
By their numbers in this assay, from the lowest: compound 3; then compounds 1 and 2 (each within the scatter of the next).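

In this assay the group on an oxygen on an aromatic ring proves to matter: (pyridin-3-yl)carbamoyl in place of (methoxycarbonyl)methyl gives a 17-fold lower number from compound 2 to compound 3 (1.23 log units; beyond the scatter) on an unchanged core. Within the data shown here, the earlier compounds offered no single-place pair, so this is the first readable step at this position, and it is large. Nothing available explains the step.

Still open, from the compounds shown here alone, is whether the step follows the pyridine ring or the carbamoyl link; a phenyl carbamoyl group and a pyridin-3-ylmethyl ether would separate the two.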